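The source may report more compounds than this note shows. Statements on the series, on what has been measured and on what is new or still open speak of the compounds shown alone.

Measured compounds:
compound 1 `COc1cc(N)c(Cl)cc1C(=O)NC1CCN(CC2CCN(CC(C)CN)CC2)CC1` — 14.3 nM
compound 2 `CCCC(N)C(=O)N1CCC(CN2CCC(NC(=O)c3cc(Cl)c(N)cc3OC)CC2)CC1` — 2.57 nM

In an assay on striatum for inhibition of 5-hydroxytryptamine receptor 4 (Cavia porcellus), read by radioligand binding (on this read-out lower numbers stand for stronger inhibition and higher numbers for weaker inhibition), compound 1 gives 14.3 nM, the highest of the two numbers in hand. The nearest neighbour is compound 2, reached by a 5.6-fold lower number from compound 1 to compound 2 (0.75 log units; beyond the scatter), where (1-aminobutyl)carbonyl stands in place of 2-(aminomethyl)propyl on the amine nitrogen in a ring.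

Compound 3 `COc1cc(N)c(Cl)cc1C(=O)NC1CCN(CC2CCN(CC(O)CN)CC2)CC1` is not yet measured. It differs from compound 1 by hydroxy in place of methyl on a saturated chain carbon bound to two saturated chain carbons; the ring nitrogen and the amine-bearing end of the chain are kept as in compound 1.

Within the data shown here, only one measured step is available, and it touches the same end of the molecule, but it exchanges the whole chain for a carbonyl-bearing group rather than altering one substituent within the chain, so it bears on the present change only loosely. Among the measured compounds shown here, no measured pair shows hydroxy in place of methyl. For compound 3 the expected step is therefore small, a 1.2-fold lower number from compound 1 to compound 3 (0.08 log units; within the scatter), not beyond the scatter in either direction. In this assay compound 3 is estimated at 12 nM, with a range of 4 nM to 40 nM.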

Compound 3, half-maximal inhibitory concentration: 14.4 nM
Compound 3: middle estimate off by 1.2-fold (0.08 log units), on the low side; the measured number falls inside the stated range.
By their numbers in this assay, from the lowest: compound 2; then compounds 1 and 3 (each within the scatter of the next).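

In this assay, among these compounds, the exchange of hydroxy for methyl on a saturated chain carbon bound to two saturated chain carbons gives a 1.0-fold higher number from compound 1 to compound 3 (0.00 log units; within the scatter), the first reading of a change made within the chain rather than of the whole chain; at this position, the two groups cannot be told apart on this read-out, even though hydroxy brings a hydrogen-bond donor and a hydrogen-bond acceptor that methyl lacks. The separate step a 5.6-fold higher number from compound 2 to compound 3 (0.75 log units; beyond the scatter) matches what the earlier pair showed for the 2-(aminomethyl)propyl chain, so among these three compounds only the (1-aminobutyl)carbonyl group of compound 2 stands apart beyond the scatter. No supporting information bears on why hydroxy and methyl read alike here.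

Still open, from the compounds shown here alone, is whether this tolerance holds for other groups on the same carbon, such as methoxy, an amine, fluorine or a longer chain such as ethyl, or whether it extends only to hydroxy and methyl. Also open is which feature of the (1-aminobutyl)carbonyl group accounts for its separation, since its carbonyl and its propyl-length side chain change together in the steps shown here.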